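Carboxy to hydroxy-oxazole on a phenoxy-bearing core

A few compounds are considered here, and "the series" means these few. Any claim that something is new, unique, unknown or untested is made for them only; others in the source may bear on it.

Among the three numbers shown in an assay on isolated protein for inhibition of Flap endonuclease 1 (Homo sapiens) (a higher number here means a weaker inhibitor, a lower number a stronger inhibitor), compound 2 `O=C(O)C(=O)CC(=O)c1ccc(Oc2ccccc2)cc1` gives 1750 nM, the lowest, although the step of a 2.0-fold lower number from compound 1 to compound 2 (0.30 log units; within the scatter) is within the scatter; compound 1 `O=C(O)C(=O)CC(=O)c1ccc(-c2ccccc2)cc1` gives 3500 nM in this assay. Compound 3 `CCOc1ccc(-c2ccc(C(=O)CC(=O)C(=O)O)o2)cc1`, built on a different core, gives 11300 nM in this assay. Compound 4 `O=C(CC(=O)c1cc(O)no1)c1ccc(Oc2ccccc2)cc1` carries 3-hydroxy-1,2-oxazol-5-yl in place of carboxy on a carbonyl carbon. Among the measured compounds shown here, no measured step bears on this part of the molecule: the single one-place step among the measured compounds alters a ring substituent and stays within the scatter. Nothing measured therefore fixes the size or direction of the change, and the expected value for compound 4 in this assay is estimated at 2500 nM, between 800 nM and 8000 nM. That estimate corresponds to an expected step of a 1.4-fold higher number from compound 2 to compound 4 (0.15 log units; within the scatter), within the scatter.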

Compound 4, half-maximal inhibitory concentration: > 100000 nM
Compound 4: only a limit was reported; the forecaster's own chance of this, stated with the estimate: 5%; at least 40-fold (1.60 log units) between middle value and limit.
By their numbers in this assay, from the lowest: compounds 2 and 1 (each within the scatter of the next); then compound 3. At a limit, above all of these: compound 4.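

Replacing carboxy with 3-hydroxy-1,2-oxazol-5-yl on a carbonyl carbon gives an at least 57-fold higher number from compound 2 to compound 4 (1.75 log units; beyond the scatter) in this assay, so this position responds strongly to this change, whereas the earlier step, a 2.0-fold lower number from compound 1 to compound 2 (0.30 log units; within the scatter), altered a ring substituent. Compound 4 gives only a limit of the assay, so the full size of this step stays unknown: the limit of > 100000 nM in this assay, at which 1 of the 4 values shown sits.

The compounds shown leave open whether a methyl ester, a primary amide or a tetrazole in place of carboxy would keep the number close to that of compound 2. They also leave open whether the same replacement would have a similar effect on the core of compound 3.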